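Bromo to nitro on the aryl ketone of compound 1

The source may hold more compounds than are shown below. What is called first, only, known or untested is meant among the compounds shown, and "the series" means these compounds.

Measured so far:
Compound 1 `O=C(/C=C/c1ccc(OCc2cn(Cc3ccccc3)nn2)cc1)c1ccc(Br)cc1`: in a functional assay on A549 cells (Homo sapiens) for inhibition, read by MTT assay, with a stated time of 48 h, tested at 10 uM (on this read-out higher numbers stand for more inhibition of growth at the one concentration tested and lower numbers for less inhibition of growth), compound 1 gives 34%.
Compound 2 `O=C(/C=C/c1ccc(OCc2cn(Cc3ccccc3F)nn2)cc1)c1ccc(Br)cc1`: in this assay compound 2 gives 38%.

Compound 1 holds the lower of the two measured numbers, but the step of a number 4 percentage points higher from compound 1 to compound 2 (within the scatter) is within the scatter, so the two compounds cannot be ordered against each other. Compound 3 `O=C(/C=C/c1ccc(OCc2cn(Cc3ccccc3)nn2)cc1)c1ccc([N+](=O)[O-])cc1` differs from compound 1 by nitro in place of bromo on an aromatic carbon. Going by the values given here, the only measured step, from compound 1 to compound 2, concerns a fluoro for hydrogen exchange elsewhere in the molecule and says nothing about a nitro in place of bromo; no measured pair shows that exchange. With nothing to ground a direction, the expected step in this assay is one that stays within the scatter, estimated as a number 2 percentage points higher from compound 1 to compound 3 (within the scatter). Compound 3 is accordingly expected to give about 36%, with a range from 15% to 60%.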

Compound 3, percent growth inhibition at one concentration: "not active" (no number reported)
Compound 3: no number reported, so the estimate cannot be set against anything.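

Going by these compounds alone, compound 3 is reported without a number in this assay, and no step from compound 1 to compound 3 can be read. The compounds shown leave open how 4-nitrophenyl in place of 4-bromophenyl compares on growth inhibition. No evidence at hand bears on this result.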